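The source may hold more compounds than are shown below. What is called first, only, known or untested is meant among the compounds shown, and "the series" means these compounds.

Measured in a functional assay on NUGC-3 cells (Homo sapiens) for antiproliferative activity, read by sulforhodamine B assay; a higher number here means a weaker inhibitor of growth, a lower number a stronger inhibitor of growth:
Compound 1 `CC(C)=CCOc1cccc(O)c1C(=O)/C=C/c1ccc(O)cc1`: > 30000 nM, a limit
Compound 2 `O=C(/C=C/c1ccc(O)cc1)c1c(O)cccc1OCCC1CCCCC1`: > 30000 nM, a limit
Compound 3 `CCC(CC)COc1cccc(O)c1C(=O)/C=C/c1ccc(O)cc1`: 1960 nM

For the measured compounds named here, compound 3 is the only compound here with a number, 1960 nM. The other two stand at the limit of > 30000 nM in this assay, at which 2 of the 3 values shown sit.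

Compound 4 `CC(C)COc1cccc(O)c1C(=O)/C=C/c1ccc(O)cc1` carries isopropyl in place of pentan-3-yl on a saturated chain carbon bound to an oxygen on an aromatic ring.

Two measured steps at this place bear on the change, an at least 15-fold lower number from compound 1 to compound 3 (1.18 log units; beyond the scatter) and an at least 15-fold lower number from compound 2 to compound 3 (1.18 log units; beyond the scatter), and both are large. The step that the two limits leave unreadable from compound 1 to compound 2 cannot be read. Leaving compound 3 is therefore expected to give a sizeable move to a higher number in this assay, though the size of that move remains uncertain.

The expected move is a 3.6-fold higher number from compound 3 to compound 4 (0.55 log units; beyond the scatter).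

For compound 4 the estimated value is 7000 nM, with an expected range of 2000 nM to 25000 nM.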

Compound 4, concentration for 50% growth inhibition: 2980 nM
Estimate against measurement, compound 4: 2.3-fold (0.37 log units) above; measured number inside the range.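

In this assay, isopropyl and pentan-3-yl read alike on this saturated chain carbon: a 1.5-fold higher number from compound 3 to compound 4 (0.18 log units; within the scatter). The large gap seen with pentan-3-yl therefore recurs with the smaller isopropyl: an at least 10-fold lower number from compound 2 to compound 4 (1.00 log units; beyond the scatter), and an at least 10-fold lower number from compound 1 to compound 4 (1.00 log units; beyond the scatter). Both of these steps start from a limit rather than a number: the limit of > 30000 nM in this assay, at which 2 of the 4 values shown sit.

The compounds shown leave open whether an unbranched butyl chain, or a chain ending in an amine, would sit at the same level. They also leave open how far a branched group can grow here before the activity is lost.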